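The compounds below may be only part of what the source reports. "The series", "measured", "known", "first", "only" and "open" are said of these compounds alone.

The series rests on a shared core carrying two phenyl groups and a nitrile, seen in compound 1 `COc1ccc(COc2c(-c3ccccc3)c(-c3ccccc3)n3ccc(C#N)cc23)cc1`, compound 2 `N#Cc1ccn2c(-c3ccccc3)c(-c3ccccc3)c(OCOCc3ccccc3)c2c1` and compound 3 `COc1ccc(C(O)c2c(-c3ccccc3)c(-c3ccccc3)n3ccc(C#N)cc23)cc1`. In an assay for inhibition of Polyunsaturated fatty acid lipoxygenase ALOX15 (Oryctolagus cuniculus) (on this read-out higher numbers stand for weaker inhibition and lower numbers for stronger inhibition), compound 2 gives 39000 nM. In this assay compound 3 gives "not determined" (no result reported), and compound 1 gives "not determined" (no result reported), so compound 3 stands without a value against which a step could be read. Compound 4 `N#Cc1ccn2c(-c3ccccc3)c(-c3ccccc3)c(Cc3ccccc3)c2c1` differs from compound 3 by benzyl in place of hydroxy(4-methoxyphenyl)methyl on an aromatic carbon. With no number for compound 3, no direction for this change in this assay can be stated beyond expecting weak inhibition, as compound 2 shows with 39000 nM. Compound 4 is therefore estimated at 30000 nM, with a range of 8000 nM to 120000 nM.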

Compound 4, half-maximal inhibitory concentration: 46000 nM
Estimate against measurement, compound 4: 1.5-fold (0.19 log units) below, within the range that was stated.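

In this assay, the benzyl of compound 4 and the (benzyloxy)methoxy of compound 2 on this aromatic carbon cannot be told apart, with a 1.2-fold higher number from compound 2 to compound 4 (0.07 log units; within the scatter). This position now holds two groups with numbers, and both leave inhibition weak, which compound 2 alone could not show. Nothing at hand explains this result. With no single number for compound 3, the change from hydroxy(4-methoxyphenyl)methyl to benzyl cannot be read. On these data alone, whether an amine or a carboxylic acid on this carbon would give stronger inhibition stays open.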